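The source may hold more compounds than are shown below. What is called first, only, known or untested is meant among the compounds shown, and "the series" means these compounds.

Measured so far in a functional assay on a cell-free system (plasma) with sterol O-acyltransferase, Soat (Rattus norvegicus) as the target; on this read-out higher numbers stand for an effect only at larger amounts of compound and lower numbers for an effect already at smaller amounts:
Compound 1, `Cc1cc(C)c(NC(=O)N(Cc2ccc(-c3ccccc3)o2)C2CCCCCC2)c(C)c1`, gave < 1 mg/kg, which is a limit of the assay rather than a number.
Compound 2, `Cc1cc(C)c(NC(=O)N(Cc2ccc(-c3nnc(C)o3)cc2)C2CCCCCC2)c(C)c1`, gave > 0.32 mg/kg, again a limit of the assay.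
Compound 3, `CSc1cc(C)nc(SC)c1NC(=O)N(Cc1ccc(N(C)C)cc1)Cc1cccc(-c2cc[nH]n2)c1`, gave < 0.1 mg/kg, also a limit of the assay.

Compound 2 therefore stands only at a limit, namely (the limit of > 0.32 mg/kg in this assay, at which 1 of the 3 values shown sits). The two other values are limits as well, the limit of < 1 mg/kg in this assay, at which 1 of the 3 values shown sits, and (the limit of < 0.1 mg/kg in this assay, at which 1 of the 3 values shown sits), so none of the three can be ranked against another. Compound 4, `Cc1cc(C)c(NC(=O)N(Cc2ccc(-c3ccccn3)cc2)C2CCCCCC2)c(C)c1`, has not yet been measured. It differs from compound 2 in one place: pyridin-2-yl in place of 5-methyl-1,3,4-oxadiazol-2-yl on an aromatic carbon. No measured step joins any two of the compounds shown, so there is no measured step to lean on. The change is expected to move the dose in this assay little, if at all, beyond the usual scatter, perhaps slightly upward. The expected step is a step that the limit leaves unreadable from compound 2 to compound 4. Compound 4 is accordingly estimated at 1 mg/kg, with a range from 0.3 mg/kg to 3 mg/kg.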

Compound 4, dose for half-maximal effect: > 1 mg/kg
Compound 4: only a limit was reported (the forecaster's own chance of this, stated with the estimate: 50%); the middle value sits exactly at the limit.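

Within the data shown here, compound 2 and compound 4 each stand only at a limit, so no step between them can be read. On these data alone, whether pyridin-2-yl or 5-methyl-1,3,4-oxadiazol-2-yl gives the lower half-maximal dose stays open.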